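From Acetyl to Methylsulfanyl in a Ketone Series

This account rests on a few compounds, and the source may have more. Where it says the series, first, only, none or still open, it means among the compounds named here.

Compound 3 `CC(=O)c1cnc(C(=O)CCCCCCc2ccccc2)o1` is one of three ketones that share the same phenyl-ended side chain joined to a small heteroaromatic head group. In an assay on HEK-293T cells for inhibition of diacylglycerol lipase-alpha (Homo sapiens), read by colorimetric assay (a lower number here means a stronger inhibitor, a higher number a weaker inhibitor), compound 3 gives only a limit, > 10000 nM. Compound 1 `O=C(CCCCCCc1ccccc1)c1nnn[nH]1` likewise stands at a limit in this assay, > 10000 nM; > 10000 nM (2 entries). Compound 2 `O=C(CCCCCCc1ccccc1)c1ncno1` also returns a limit, > 10000 nM. No measured number therefore exists in this set, and the picture is summed up by the limit of > 10000 nM in this assay, at which 2 of the 3 values shown sit.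

Compound 4 `CSc1cnc(C(=O)CCCCCCc2ccccc2)o1` differs from compound 3 by methylsulfanyl in place of acetyl on an aromatic carbon. Among the measured compounds shown here, no step between measured compounds is available to gauge this exchange, and the three values at hand offer no direction. The step from compound 3 to compound 4 is expected to be a step that the limit leaves unreadable from compound 3 to compound 4, within the scatter. Compound 4 is therefore estimated at 15000 nM, with a range from 3000 nM to 100000 nM, and most probably this assay will again report only a limit.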

Compound 4, half-maximal inhibitory concentration: > 10000 nM
Compound 4: a limit, no number; the forecaster's own chance of this, stated with the estimate: 75%; the middle value lies beyond the limit too.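

In this assay compound 4 gives only a limit, and the steps to it from compound 3 and from compound 2 cannot be read. The compounds shown leave open whether any of these head groups gives a measurable inhibition, and the picture stays as it was: the limit of > 10000 nM in this assay, at which 3 of the 4 values shown sit.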